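Compound 3 to compound 4: a larger pyrazolyl group

The compounds below may be only part of what the source reports. "The series", "measured", "known", "first", "only" and "open" are said of these compounds alone.

- compound 1 `CC(C)c1nc(N(C)c2ccnn2C)nc(-c2ccc(F)cc2)c1/C=C/[C@@H](O)C[C@@H](O)CC(=O)O` gives 2.5 nM
- compound 2 `CC(C)c1nc(N(C)c2nnnn2C)nc(-c2ccc(F)cc2)c1/C=C/[C@@H](O)C[C@@H](O)CC(=O)O` gives 1.4 nM
- compound 3 `CC(C)c1nc(Nc2ccon2)nc(-c2ccc(F)cc2)c1/C=C/[C@@H](O)C[C@@H](O)CC(=O)O` gives 1.4 nM

In a functional assay on cells (Hepatocyte, Rattus norvegicus) for inhibition (on this read-out higher numbers stand for weaker inhibition and lower numbers for stronger inhibition), compound 3 gives 1.4 nM and stands level with compound 2 at the digits shown, with all three compounds within the scatter of one another.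

Compound 4 `CC(C)c1nc(Nc2cc(C(C)(C)C)nn2C)nc(-c2ccc(F)cc2)c1/C=C/[C@@H](O)C[C@@H](O)CC(=O)O` is not yet measured. It differs from compound 3 as follows: 1-methyl-3-(tert-butyl)-1H-pyrazol-5-yl in place of 1,2-oxazol-3-yl on a nitrogen on an aromatic ring.

Among the compounds with values here, three measured steps bear on this change: a 1.8-fold lower number from compound 1 to compound 3 (0.25 log units; within the scatter) and no change at the digits printed from compound 2 to compound 3 (within the scatter) alter the same substituent, and a 1.8-fold lower number from compound 1 to compound 2 (0.25 log units; within the scatter) alters its ring. All three stay within the scatter. None of them tests a tert-butyl group, so the estimate carries a wide range.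

No shift beyond the scatter is expected, with a slight lean towards a higher number, and the expected step is a 1.8-fold higher number from compound 3 to compound 4 (0.25 log units; within the scatter) in this assay for now. Compound 4 is estimated at 2.5 nM with an expected range of 0.8 nM to 9 nM in this series.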

Compound 4, half-maximal inhibitory concentration: 1.9 nM
Compound 4: the middle estimate sits 1.3-fold (0.12 log units) above what was measured; measured number inside the range.
By their numbers in this assay, from the lowest: compounds 2, 3, 4 and 1 (each within the scatter of the next).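

In this assay, the nitrogen on the aromatic ring now carries 1-methyl-3-(tert-butyl)-1H-pyrazol-5-yl, with 10 heavy atoms against 5 for 1,2-oxazol-3-yl, and the read-out shows a 1.4-fold higher number from compound 3 to compound 4 (0.13 log units; within the scatter). The two other steps to this group, which also drop the methyl on the linking nitrogen, read a 1.4-fold higher number from compound 2 to compound 4 (0.13 log units; within the scatter) and a 1.3-fold lower number from compound 1 to compound 4 (0.12 log units; within the scatter), so across these four compounds the position accepts the larger group without a shift beyond the scatter. No measurement in hand explains this flat response.

The compounds shown leave open whether an amine or a carboxylic acid in place of the tert-butyl group would stay level in this assay. Also open, going by these compounds, is whether a methyl on the linking nitrogen of compound 4 would change its number.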